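A Ring for a Chain on a Shared Core

The source may report more compounds than this note shows. Statements on the series, on what has been measured and on what is new or still open speak of the compounds shown alone.

Compound 1 `COc1ccc(-c2c(-c3ccc(OC)cc3)n(Cc3ccccc3)c3ncn(CCCO)c(=N)c23)cc1` and compound 2 `COc1ccc(-c2c(-c3ccc(OC)cc3)n(Cc3ccccc3)c3ncn([C@H]4CC[C@H](O)CC4)c(=N)c23)cc1` share one core and differ in a single place: 4-hydroxycyclohexyl in place of 3-hydroxypropyl on an aromatic nitrogen. In a functional assay on PC-3M cells (Homo sapiens) for antiproliferative activity, read by microscopy, with a stated time of 24 h (on this read-out higher numbers stand for weaker inhibition and lower numbers for stronger inhibition), compound 1 gives > 20000 nM, which is a limit of the assay rather than a number. In this assay compound 2 likewise gives > 20000 nM, again a limit. The size of the step that the two limits leave unreadable from compound 1 to compound 2 therefore cannot be read, because both values sit at the limit of > 20000 nM in this assay, at which 3 of the 3 values shown sit.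

Compound 3 `Cc1c(C)n(Cc2ccccc2)c2ncn(CCCO)c(=N)c12` carries a different core; how that core differs from the core of compound 1 is not broken down here. In this assay compound 3 gives > 20000 nM, a limit of the assay. Compound 4 `Cc1c(C)n(Cc2ccccc2)c2ncn([C@H]3CC[C@H](O)CC3)c(=N)c12` has not yet been measured; it differs from compound 3 by 4-hydroxycyclohexyl in place of 3-hydroxypropyl on an aromatic nitrogen, the same change that separates compound 1 from compound 2.

Set beside the earlier unreadable step, the step expected here is a step that the limit leaves unreadable from compound 3 to compound 4, which would leave compound 4 where compound 3 stands. For the measured compounds named here, because every value so far rests at the limit of > 20000 nM in this assay, at which 3 of the 3 values shown sit, compound 4 is expected at 30000 nM, most likely as a limit once more, within a range from 8000 nM to 100000 nM.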

Compound 4, half-maximal inhibitory concentration: > 20000 nM
Compound 4: no number, only a limit (the forecaster's own chance of this, stated with the estimate: 85%); the middle value does not contradict the limit.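

For the compounds shown here, compound 3 and compound 4 both stop at a limit in this assay rather than at a number, so no step between them can be read: the limit of > 20000 nM in this assay, at which 4 of the 4 values shown sit.

The compounds shown leave open whether 4-hydroxycyclohexyl in place of 3-hydroxypropyl changes antiproliferative activity on either core, and which structures on these cores would give a measurable value.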